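The compounds below may be only part of what the source reports. "The series", "measured", "known", "first", "only" and "open" are said of these compounds alone.

Compound 1 `C[C@@H](Cn1ccc(-c2ccc(C#N)c(Cl)c2)n1)NC(=O)c1ccccc1` was tested in an ADME assay on PC-3 cells (Homo sapiens) for cytotoxicity, read by CCK-8 assay, with a stated time of 6 days; a higher number here means a weaker inhibitor, a lower number a stronger inhibitor. In this assay compound 1 gives > 30000 nM, which is a limit of the assay rather than a number. Two related compounds share its core. Compound 2 `C[C@@H](Cn1ccc(-c2ccc(C#N)c(Cl)c2)n1)NC(=O)c1cccc(OCC(O)CO)c1` carries 2,3-dihydroxypropoxy in place of hydrogen on an aromatic carbon, and in this assay compound 2 gives > 30000 nM, again a limit. Compound 3 `CC(=O)c1ccc(C(=O)N[C@@H](C)Cn2ccc(-c3ccc(C#N)c(Cl)c3)n2)cc1` carries acetyl in place of hydrogen on an aromatic carbon, and in this assay compound 3 gives > 30000 nM, also a limit. The step that the two limits leave unreadable from compound 1 to compound 2 and the step that the two limits leave unreadable from compound 1 to compound 3 cannot be sized because of the limit of > 30000 nM in this assay, at which 3 of the 3 values shown sit. Compound 4 `C[C@@H](Cn1ccc(-c2ccc(C#N)c(Cl)c2)n1)Nc1ncccn1` differs from compound 1 by pyrimidin-2-yl in place of benzoyl on an amine nitrogen. Among the compounds with values here, no measured step touches the amine nitrogen, so this change has no measured counterpart among the three compounds. With every value resting at the same limit, for compound 4 the expected step is a number no higher from compound 1 to compound 4 (the limit leaves the size open), most likely nothing readable. Compound 4 is expected to give about 30000 nM, between 10000 nM and 60000 nM.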

Compound 4, half-maximal inhibitory concentration: > 30000 nM
Compound 4 gave a limit, no number; the forecaster's own chance of this, stated with the estimate: 80%; the middle value sits exactly at the limit.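

No step can be read from compound 1 to compound 4, because both rest at the same limit rather than at a number: the limit of > 30000 nM in this assay, at which 4 of the 4 values shown sit. The compounds shown leave open how strongly any of them acts in this assay and which change to the shared core would give a readable value.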